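The source may hold more compounds than are shown below. What is called first, only, known or untested is meant among the compounds shown, and "the series" means these compounds.

Compound 1 `O=C1/C(=C/c2cccc([N+](=O)[O-])c2)CN(S(=O)(=O)c2ccc(F)cc2)C/C1=C\c1cccc([N+](=O)[O-])c1` measured at 11900 nM
Compound 2 `CC(=O)Nc1ccc(S(=O)(=O)N2C/C(=C\c3cccc([N+](=O)[O-])c3)C(=O)/C(=C/c3cccc([N+](=O)[O-])c3)C2)cc1` measured at 6760 nM
Compound 3 `COc1cc(/C=C2\CN(S(=O)(=O)c3ccc(F)cc3)C/C(=C\c3ccccc3F)C2=O)cc(OC)c1OC` measured at 13300 nM

All three values come from a functional assay on QGY-7703 cells (Homo sapiens) for cytotoxicity, read by MTT assay, with a stated time of 24 h; on this read-out higher numbers stand for weaker inhibition and lower numbers for stronger inhibition. Compound 2 stands level with the other two: its gaps to compound 1 and to compound 3 both lie within the usual scatter. The next compound is compound 4 `CC(=O)Nc1ccc(S(=O)(=O)N2C/C(=C\c3cccc([N+](=O)[O-])c3)C(=O)/C(=C/c3ccccc3F)C2)cc1`, which carries 2-fluorophenyl in place of 3-nitrophenyl on a double-bonded chain carbon bound to a double-bonded ring carbon. Going by the values given here, no measured step makes this exact exchange. Among the compounds with values here, the one measured step, a 1.8-fold lower number from compound 1 to compound 2 (0.25 log units; within the scatter), concerns another place, and it stayed within the scatter. Compound 3 also carries 2-fluorophenyl, though it differs elsewhere too, and compound 3 gives 13300 nM, a value within the scatter of compound 2. No change beyond the scatter is therefore expected in this assay. The expected size is a 1.3-fold higher number from compound 2 to compound 4 (0.10 log units; within the scatter), in no firm direction. The estimated value for compound 4 is 8500 nM, with an expected range from 3500 nM to 20000 nM.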

Compound 4, half-maximal inhibitory concentration: 7850 nM
Estimate against measurement, compound 4: 1.1-fold (0.03 log units) above, within the range that was stated.
By their numbers in this assay, from the lowest: compounds 2, 4, 1 and 3 (each within the scatter of the next).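

Swapping 3-nitrophenyl for 2-fluorophenyl on a double-bonded chain carbon bound to a double-bonded ring carbon gives the first direct reading at this position in this assay (a 1.2-fold higher number from compound 2 to compound 4 (0.06 log units; within the scatter)). The number stays level even though the 3-nitrophenyl group, with its hydrogen-bond acceptors, gives way to a smaller group that has none, so in this one pair the read-out does not depend on which of the two groups sits here. The evidence available offers no explanation for this level result.

As far as these compounds go, compound 4 still carries a second 3-nitrophenyl, so the effect of exchanging that group remains open. It is also unknown whether an aminophenyl or a carboxyphenyl at this position would keep the number level.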